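The source may report more compounds than this note shows. Statements on the series, on what has been measured and on what is new or still open speak of the compounds shown alone.

Compound 1 `Nc1cc(-c2ccc(Cl)cc2)nn1-c1ccc(Br)cc1` gives 61300 nM in a functional assay on Jurkat cells (Homo sapiens) for inhibition, read by MTT assay, with a stated time of 72 h (on this read-out lower numbers stand for stronger inhibition of growth and higher numbers for weaker inhibition of growth), a weak result on that scale. Compound 2 `Cc1ccc(-c2cc(/N=C/N(C)C)n(-c3ccc(Br)cc3)n2)cc1` reaches only a limit in this assay, > 100000 nM. This limit, (the limit of > 100000 nM in this assay, at which 1 of the 2 values shown sits), is where compound 2 stands: no number was obtained for it, only the statement that any growth inhibition lies beyond what the assay could resolve. Compound 3 `CN(C)/C=N/c1cc(-c2ccc(Cl)cc2)nn1-c1ccc(Br)cc1` is made from compound 2 by one change, (chloro in place of methyl on an aromatic carbon), that is, chloro in place of methyl on an aromatic carbon, para to a large group. Among the measured compounds shown here, no measured pair in this set shares this change, so its size in this assay is unknown. A step of no more than the usual scatter, in either direction, is expected. Compound 3 is therefore expected to remain near the limit, with an estimated step of a number no higher from compound 2 to compound 3 (the limit leaves the size open). Compound 3 is estimated at 100000 nM, with a range from 40000 nM to 300000 nM.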

Compound 3, concentration for 50% growth inhibition: 84900 nM
Compound 3: the middle estimate sits 1.2-fold (0.07 log units) above what was measured; low and high end bracket the measured number.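

The 4-methylphenyl to 4-chlorophenyl change now has a measured number at its chloro end, and in this assay it gives an at least 1.1-fold lower number from compound 2 to compound 3 (0.07 log units; that floor lies within the scatter), so the true size of the change stays unresolved. Among the compounds shown here, compound 2 gives only a limit of the assay and not a number: the limit of > 100000 nM in this assay, at which 1 of the 3 values shown sits. The earlier compounds also gave no view of how much the group on the other aromatic carbon matters with the 4-chlorophenyl held fixed, and placing a group of 5 heavy atoms there instead of one nitrogen atom gives a 1.4-fold higher number from compound 1 to compound 3 (0.14 log units; within the scatter).

From the compounds shown here alone, what a fluoro, a methoxy or a carboxylic acid would do in place of chloro at this place on the ring remains open. So does whether an amide or a longer chain on the other aromatic carbon would move the number beyond the scatter.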